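Azocane to cyclopentyloxy exchange on the benzylamide core

The compounds below may be only part of what the source reports. "The series", "measured", "known", "first", "only" and "open" are said of these compounds alone.

Compound 1 `CC(C(=O)NCc1ccc(C(F)(F)F)cc1N1CCCCCCC1)c1ccc(NS(C)(=O)=O)c(F)c1` carries an eight-membered non-aromatic ring with one hetero atom on the aromatic carbon that sits ortho to a large group and meta to the trifluoromethyl group. In an assay on CHO cells for antagonist activity at transient receptor potential cation channel subfamily V member 1 (Homo sapiens), read by FLIPR (a higher number here means a weaker inhibitor, a lower number a stronger inhibitor), compound 1 gives 2.8 nM. Compound 2 `Cc1ccc(N2CCN(c3cc(C(F)(F)F)ccc3CNC(=O)C(C)c3ccc(NS(C)(=O)=O)c(F)c3)CC2)cc1` gives 0.7 nM and compound 3 `Cc1cccc(N2CCN(c3cc(C(F)(F)F)ccc3CNC(=O)C(C)c3ccc(NS(C)(=O)=O)c(F)c3)CC2)c1` gives 1.8 nM in this assay. Compound 1 thus shows the highest of the three numbers; its gap to compound 3 lies within the scatter, while the gap to compound 2 lies beyond it. Among the compounds with values here, the single measured step, a 2.6-fold higher number from compound 2 to compound 3 (0.41 log units; beyond the scatter), concerns the methylphenyl on the amine nitrogen in a ring and does not touch the position changed here.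

Compound 4 `CC(C(=O)NCc1ccc(C(F)(F)F)cc1OC1CCCC1)c1ccc(NS(C)(=O)=O)c(F)c1` differs from compound 1 by a group of 6 heavy atoms (5 carbon, 1 oxygen; one five-membered non-aromatic ring of carbon only) in place of a group of 8 heavy atoms (7 carbon, 1 nitrogen; one eight-membered non-aromatic ring with 1 hetero atom), on an aromatic carbon. Within the data shown here, no measured step bears on this exchange, so the expectation rests on compound 1 alone, with the spread of the three numbers as a guide to how far a single change may move the value. Compound 4 is expected to give about 5 nM (range 1.5 nM to 18 nM) in this assay. This estimate means a 1.8-fold higher number from compound 1 to compound 4 (0.25 log units; within the scatter), expected to stay close to the scatter rather than clearly beyond it.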

Compound 4, inhibition constant: 0.6 nM
For compound 4 the middle estimate is 8.3-fold (0.92 log units) above the measured one; the whole stated range lies above it.
By their numbers in this assay, from the lowest: compounds 4 and 2 (each within the scatter of the next); then compounds 3 and 1 (each within the scatter of the next).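

In this assay, within the data shown here, exchanging the eight-membered ring for cyclopentyloxy on this aromatic carbon gives a 4.7-fold lower number from compound 1 to compound 4 (0.67 log units; beyond the scatter), the first measured step at this position, and it lies beyond the scatter. The position therefore responds to the group placed on it, and a group with fewer heavy atoms and no ring nitrogen is compatible with a low number: compound 2 at 0.7 nM and compound 4 at 0.6 nM lie within the scatter of each other, despite their very different groups. No available evidence accounts for the step.

Ring size and the atom joined to the aromatic carbon change together here, so their separate contributions remain unresolved. A cyclopentylamino group, or an open chain such as butoxy, would bear directly on each of these.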